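A few compounds are considered here, and "the series" means these few. Any claim that something is new, unique, unknown or untested is made for them only; others in the source may bear on it.

Four compounds are compared here. Compound 1 is `ClCc1cccc(Cn2cnc3ncnc(Cl)c32)c1` and compound 2 is `ClCc1cccc(Cn2cnc3c(Cl)ncnc32)c1`; the two contain the same atoms joined differently, and the difference between their cores is not broken down here. Compound 3, `ClCc1cccc(Cn2cnc3c(Cl)nc(Cl)nc32)c1`, is compound 2 with chloro in place of hydrogen on an aromatic carbon. Compound 4, `ClCc1cccc(Cn2cnc3nc(Cl)nc(Cl)c32)c1`, is compound 1 with chloro in place of hydrogen on an aromatic carbon, the same change, at a place described in exactly the same words.

In a functional assay on A549 cells (Homo sapiens) for cytotoxicity, read by sulforhodamine B assay, with a stated time of 48 h (a lower number here means that less compound is tolerated, a higher number that more compound is tolerated), compound 1 gives 91200 nM, compound 2 gives 79400 nM and compound 3 gives 52500 nM. Going by the values given here, the one measured step that isolates the added chlorine, from compound 2 to compound 3, is a 1.5-fold lower number from compound 2 to compound 3 (0.18 log units; within the scatter).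

For compound 4 the step of a 1.5-fold lower number from compound 1 to compound 4 (0.18 log units; within the scatter) is expected, because the same change gave a 1.5-fold lower number from compound 2 to compound 3 (0.18 log units; within the scatter) when made on the other core. Compound 4 is therefore estimated at 60000 nM, with a likely range from 30000 nM to 120000 nM. Whether the measured number for compound 4 falls in that range is the open question that the next measurement will answer.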

Compound 4, concentration lethal to 50% of the cells: 55000 nM
Estimate against measurement, compound 4: 1.1-fold (0.04 log units) above; the range from low to high includes it.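

Putting the chloro group on the core of compound 1 gives a 1.7-fold lower number from compound 1 to compound 4 (0.22 log units; within the scatter) in this assay, a step too small to be told apart from the ordinary differences between repeated measurements. Set beside the earlier step on the other core, the change reads alike in both places: the same change on two cores in this assay, a 1.5-fold lower number (0.18 log units; within the scatter) from compound 2 to compound 3 and a 1.7-fold lower number (0.22 log units; within the scatter) from compound 1 to compound 4, 1.1-fold (0.04 log units) apart, within the scatter of two such steps This shows that the two steps agree, but not that the added chloro group has any real effect on how much compound the cells tolerate, since two steps that each lie within the scatter can match without either being a true change, and two cores are too few to support a rule for the series.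

The compounds shown leave open whether another group on that aromatic carbon between two ring nitrogen atoms, such as an amine, a carboxylic acid or a longer chain, would give a step beyond the scatter. They also leave open whether the agreement would hold on any core beyond these two.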